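A few compounds are considered here, and "the series" means these few. Any claim that something is new, unique, unknown or untested is made for them only; others in the source may bear on it.

Values so far in a functional assay on cells (Cancer cell lines, Homo sapiens) for inhibition; on this read-out lower numbers stand for stronger inhibition of growth and higher numbers for weaker inhibition of growth 
- Compound 1 `Cc1cn2c(/C=N/Nc3ccccn3)c(-c3ccc(Cl)c([N+](=O)[O-])c3)nc2s1` gives 11500 nM 
- Compound 2 `Cc1cn2c(/C=N/NC(=N)N)c(-c3ccsc3)nc2s1` gives 13800 nM 
- Compound 3 `N=C(N)N/N=C/c1c(-c2ccsc2)nc2sccn12` gives 15100 nM 

Compound 2 lies within the scatter of both compound 1 and compound 3, so no order can be read among the three values. Compound 4 `Cc1cn2c(/C=N/NC(=N)N)c(-c3cccs3)nc2s1` differs from compound 2 in a single change, thiophen-2-yl in place of thiophen-3-yl on an aromatic carbon. The two have the same atoms, joined differently.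

For the measured compounds named here, no measured step tests this swap directly. Going by the values given here, the only step available is a different change, hydrogen in place of methyl on an aromatic carbon (a 1.1-fold higher number from compound 2 to compound 3 (0.04 log units; within the scatter)), and it stays within the scatter. Set against compound 2, from which it differs in more than one place, compound 1 still gives 11500 nM in the same range. On this evidence, no step beyond the scatter is expected in this assay, and no direction is favoured with any confidence. The expected step is a 1.3-fold lower number from compound 2 to compound 4 (0.10 log units; within the scatter) on this read-out. For compound 4 the estimated value is 11000 nM within an expected range of 4500 nM to 26000 nM on this read-out.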

Compound 4, concentration for 50% growth inhibition: 7760 nM
The estimate for compound 4 lay 1.4-fold (0.15 log units) above the measured number, within the range that was stated.
By their numbers in this assay, from the lowest: compounds 4, 1, 2 and 3 (each within the scatter of the next).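

In this assay, for the compounds shown here, this is the first direct reading of the thiophene ring at this position, the aromatic carbon of the five-membered aromatic ring with 2 nitrogen, and the step (a 1.8-fold lower number from compound 2 to compound 4 (0.25 log units; within the scatter)) stays within the scatter. Moving the point of attachment from thiophen-3-yl to thiophen-2-yl, with the same atoms, therefore gives no separation on this read-out, just as hydrogen in place of methyl gave none at its own position (a 1.1-fold higher number from compound 2 to compound 3 (0.04 log units; within the scatter)). No independent measurement bears on why the two thiophene isomers read alike.

On these data alone, whether an amine or a carboxylic acid on this aromatic carbon, in place of the thiophene ring, would give a step beyond the scatter stays open. Also open, as far as these compounds go, is how thiophen-2-yl reads with hydrogen in place of the methyl group.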